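The source may report more compounds than this note shows. Statements on the series, on what has been measured and on what is new or still open speak of the compounds shown alone.

Measured compounds in a functional assay on T47D cells (Homo sapiens) for cytotoxicity, read by CCK-8 assay and cell counting, with a stated time of 2 days; on this read-out lower numbers stand for stronger inhibition and higher numbers for weaker inhibition:
- compound 1 `Oc1cccc(-c2cc(-c3ccc(Cl)cc3)nc(-c3cccs3)c2)c1`: 10500 nM
- compound 2 `Oc1cccc(-c2cc(-c3ccc(Cl)cc3)nc(-c3cccnc3)c2)c1`: 18100 nM

Only these two compounds have numbers in this assay. Compound 2 sits at the top of the two, its nearest neighbour being compound 1; the gap between them, a 1.7-fold higher number from compound 1 to compound 2 (0.24 log units; within the scatter), lies within the scatter, so the two are not separated by this read-out.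

Compound 3 `Oc1cccc(-c2cc(-c3ccc(Cl)cc3)nc(-c3ccsc3)c2)c1` is not yet measured. It differs from compound 2 by thiophen-3-yl in place of pyridin-3-yl on an aromatic carbon. Going by the values given here, the one measured step that bears on this exchange is the one from compound 1 to compound 2, where a pyridin-3-yl took the place of a thiophen-2-yl and the number moved a 1.7-fold higher number from compound 1 to compound 2 (0.24 log units; within the scatter). Among the compounds with values here, the step to compound 3 reverses that exchange except that the thiophene is now attached through its other ring carbon; the single precedent gives no movement beyond the scatter in either direction, and nothing further is known about a thiophen-3-yl here.

The expectation for compound 3 in this assay is therefore a step of about a 1.5-fold lower number from compound 2 to compound 3 (0.18 log units; within the scatter), that is, no change beyond the scatter. The estimated value for compound 3 is 12000 nM, expected between 5000 nM and 28000 nM.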

Compound 3, half-maximal inhibitory concentration: 11500 nM
Compound 3: middle estimate off by 1.0-fold (0.02 log units), on the high side, and the stated range covers the measured number.
By their numbers in this assay, from the lowest: compounds 1, 3 and 2 (each within the scatter of the next).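

At the aromatic carbon next to the ring nitrogen, this assay now has a second exchange between ring types: thiophen-3-yl in place of pyridin-3-yl gives a 1.6-fold lower number from compound 2 to compound 3 (0.20 log units; within the scatter), which matches the earlier exchange in staying within the scatter. Going by these compounds alone, the point of attachment of the thiophene is also tested here for the first time, and thiophen-3-yl in place of thiophen-2-yl gives a 1.1-fold higher number from compound 1 to compound 3 (0.04 log units; within the scatter), so the read-out separates neither the two thiophene attachments nor either of them from pyridin-3-yl. No supporting data are available to explain these numbers.

From the compounds shown here alone, all three compounds carry an aromatic ring with one hetero atom at this position, so it remains open whether a plain phenyl, a basic amine such as morpholine, a carboxylic acid or a longer alkyl chain there would move the number beyond the scatter. Going by these compounds, the contribution of the 3-hydroxyphenyl and 4-chlorophenyl groups is also open, since both stay constant across the series and a methoxy in place of the hydroxyl or a hydrogen in place of the chlorine would be needed to read them.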